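Hydrogen in Place of Benzyl, Tested on Two Related Cores

This account rests on a few compounds, and the source may have more. Where it says the series, first, only, none or still open, it means among the compounds named here.

Compound 1 `CCOC(=O)c1cc(-c2cc(OC)c(OC)c(OC)c2)c(-c2ccc(OC)c(OCc3ccccc3)c2)s1`: > 100000 nM, which is a limit of the assay.
Compound 2 `CCOC(=O)c1cc(-c2cc(OC)c(OC)c(OC)c2)c(-c2ccc(OC)c(O)c2)s1`: 1580 nM.
Compound 3 `CCOC(=O)c1cc(-c2ccc(OC)c(OCc3ccccc3)c2)c(-c2cc(OC)c(OC)c(OC)c2)s1`: > 100000 nM, which is a limit of the assay.

The three compounds were tested in a functional assay on SGC-7901 cells (Homo sapiens) for antiproliferative activity, read by MTT assay, with a stated time of 72 h; a higher number here means a weaker inhibitor, a lower number a stronger inhibitor. Compound 1 reaches only a limit there. Compound 2 gives a number, and the step between them, an at least 63-fold lower number from compound 1 to compound 2 (1.80 log units; beyond the scatter), comes from one change: hydrogen in place of benzyl on an oxygen on an aromatic ring. Because (the limit of > 100000 nM in this assay, at which 2 of the 3 values shown sit), the true size of that step may be larger than the limit can show.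

Compound 3 also sits at a limit. How its core differs from that of compound 1 is not broken down here; the two share the same atoms, joined differently.

Compound 4 `CCOC(=O)c1cc(-c2ccc(OC)c(O)c2)c(-c2cc(OC)c(OC)c(OC)c2)s1` carries the same change on the core of compound 3: hydrogen in place of benzyl on an oxygen on an aromatic ring. The place of the change reads the same in both cases, so it is the same change. A step of an at least 33-fold lower number from compound 3 to compound 4 (1.52 log units; beyond the scatter) is expected from compound 3 to compound 4, resting on the size of an at least 63-fold lower number from compound 1 to compound 2 (1.80 log units; beyond the scatter), with a wider range since compound 3 gives only a limit. Compound 4 is estimated at 3000 nM, between 800 nM and 30000 nM.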

Compound 4, half-maximal inhibitory concentration: 20000 nM
For compound 4 the middle estimate is 6.7-fold (0.82 log units) below the measured one; measured number inside the range.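

In this assay the hydroxy compound again gives the lower number on the second core, with an at least 5.0-fold lower number from compound 3 to compound 4 (0.69 log units; beyond the scatter) as the step for hydrogen in place of benzyl. In the two pairs shown, then, the direction of the change carries over from one core to the other, and both steps are beyond the usual scatter of repeated measurements. Each step starts from a compound that sits at a limit of the assay rather than at a true number, so the data do not show that the change has the same size on both cores: the same change on two cores in this assay, an at least 63-fold lower number (1.80 log units; beyond the scatter) from compound 1 to compound 2 and an at least 5.0-fold lower number (0.69 log units; beyond the scatter) from compound 3 to compound 4; the limit leaves it open whether they differ.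

Only benzyl and hydrogen appear on this oxygen, so the compounds shown leave open whether a small group such as methyl or a longer chain such as propyl would behave more like benzyl or more like hydrogen. They also leave open whether an amine in place of the hydroxy would give a similar step on either core.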